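Benzylselanyl in place of methylsulfanyl on the isoxazole pair

The source may hold more compounds than are shown below. What is called first, only, known or untested is meant among the compounds shown, and "the series" means these compounds.

Of the compounds shown here, two have been measured in an ADME assay on MCF-10A cells (Homo sapiens) for cytotoxicity, read by MTT assay, with a stated time of 72 h; on this read-out lower numbers stand for stronger inhibition of growth and higher numbers for weaker inhibition of growth. Compound 1 `CS/C(=N\C(=O)c1sccc1Cl)NC(=O)c1sccc1Cl` carries two chlorothiophene carbonyl groups on the shared core and gives 23700 nM in this assay. Compound 2 `CS/C(=N\C(=O)c1ccno1)NC(=O)c1ccno1` carries two isoxazole carbonyl groups on the same core. For compound 2 this assay reports only a limit, > 100000 nM, so its true value is not known; this is the limit described by the limit of > 100000 nM in this assay, at which 1 of the 2 values shown sits, at which one of the two values sits. Compound 3 `O=C(/N=C(/NC(=O)c1ccno1)[Se]Cc1ccccc1)c1ccno1` has not yet been measured. It differs from compound 2 in one place: a group of 8 heavy atoms (7 carbon, 1 selenium; one six-membered aromatic ring of carbon only) in place of a group of 2 heavy atoms (1 carbon, 1 sulfur; no ring), on a carbon with a double bond to nitrogen. Within the data shown here, no measured pair in the set shows what such a change does, so the expected step from compound 2 to compound 3 is uncertain and is estimated as an at least 1.6-fold lower number from compound 2 to compound 3 (0.22 log units; that floor lies within the scatter). Compound 3 is expected to give about 60000 nM in this assay, within a range from 15000 nM to 200000 nM.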

Compound 3, concentration for total growth inhibition: > 100000 nM
Compound 3 ended at the assay's limit; the forecaster's own chance of this, stated with the estimate: 45%; middle value at least 1.6-fold (0.22 log units) away from the limit.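

In this assay compound 2 and compound 3 both stand at a limit, so no step can be read between them: the limit of > 100000 nM in this assay, at which 2 of the 3 values shown sit.

As far as these compounds go, whether replacing methylsulfanyl with the selenium-containing group changes the read-out at all, and in which direction, stays open.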